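Working notes: the step from compound 1 to compound 4

The source may report more compounds than this note shows. Statements on the series, on what has been measured and on what is new or still open speak of the compounds shown alone.

Values so far in an ADME assay on J774 cells (Mus musculus) for cytotoxicity, with a stated time of 72 h; on this read-out higher numbers stand for an effect only at larger amounts of compound and lower numbers for an effect already at smaller amounts:
compound 1 `COC(=O)c1c[nH]c2cc(CN3CCN(c4ccc(C(F)(F)F)cc4)CC3)c(OC)cc2c1=O`: > 20000 nM
compound 2 `COC(=O)c1c[nH]c2cc(N3CCN(c4ccc(OC)cc4)CC3)c(OC)cc2c1=O`: > 20000 nM
compound 3 `COC(=O)c1c[nH]c2cc(CN3CCN(c4ccc(C(F)(F)F)cc4)CC3)c(C)cc2c1=O`: > 20000 nM

Compound 1 stands at > 20000 nM, which is a limit and not a number. Compound 2 gives > 20000 nM, also a limit. Compound 3 gives > 20000 nM, again a limit. The series therefore has no numerical value yet, only (the limit of > 20000 nM in this assay, at which 3 of the 3 values shown sit).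

The next structure is compound 4 `COC(=O)c1c[nH]c2cc(CN3CCN(Cc4ccc(OC)cc4)CC3)c(OC)cc2c1=O`, with the change 4-methoxybenzyl in place of 4-(trifluoromethyl)phenyl on an amine nitrogen in a ring.

Among the measured compounds shown here, the only measured step is a step that the two limits leave unreadable from compound 1 to compound 3. It is methyl in place of methoxy on an aromatic carbon, a different change from this one, and it gives no size to carry over. The expectation therefore rests on the shared limit alone, and no direction can be expected. The expected step is a number no higher from compound 1 to compound 4 (the limit leaves the size open), with nothing estimated beyond the scatter. In this assay the estimate for compound 4 is 20000 nM, expected within 8000 nM to 40000 nM.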

Compound 4, half-maximal effective concentration: > 20000 nM
Compound 4 was reported as a limit; the forecaster's own chance of this, stated with the estimate: 70%; the middle value sits exactly at the limit.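

In this assay, among the compounds shown here, compound 4 gives > 20000 nM, which is a limit and not a number; compound 1 also stands at a limit, so no step between them can be read. The compounds shown leave open whether any structural change here shifts the read-out, as every value rests on one limit: the limit of > 20000 nM in this assay, at which 4 of the 4 values shown sit.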